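The source may report more compounds than this note shows. Statements on the series, on what has been measured and on what is new or still open speak of the compounds shown alone.

Notes on the series. Compound 1 `COc1ccc2c(OCCn3c(=O)oc4cc(C)ccc43)ccnc2c1` and compound 2 `COCCOc1ccc2c(OCCn3c(=O)oc4cc(C)ccc43)ccnc2c1` carry short alkoxy groups at one position of the shared core, while compound 3 `Cc1ccc2c(c1)oc(=O)n2CCOc1ccnc2cc(OCCCN3CCN(C)CC3)ccc12` carries the longer side chain ending in methylpiperazine. In a functional assay on EBC-1 cells (Homo sapiens) for inhibition, read by sulforhodamine B assay, with a stated time of 72 h (a higher number here means a weaker inhibitor, a lower number a stronger inhibitor), compound 1 gives only a limit, > 500 nM. Compound 2 likewise gives only a limit in this assay, > 500 nM. Going by the values given here, compound 3 gives 170 nM, the one actual number among the three, so it stands alone; the step that the two limits leave unreadable from compound 1 to compound 2, whereas an at least 2.9-fold lower number from compound 1 to compound 3 (0.46 log units; beyond the scatter) and an at least 2.9-fold lower number from compound 2 to compound 3 (0.46 log units; beyond the scatter) are readable only as lower bounds because of the limit of > 500 nM in this assay, at which 2 of the 3 values shown sit.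

Compound 4 `Cc1ccc2c(c1)oc(=O)n2CCOc1ccnc2cc(-c3cnn(C)c3)ccc12` is the next member: 1-methyl-1H-pyrazol-4-yl in place of 3-(4-methylpiperazin-1-yl)propoxy on an aromatic carbon. The change sits at the same position as the measured steps, and both of those favour the methylpiperazine-bearing chain over shorter groups, so its removal is expected to count against compound 4. Among the compounds with values here, no measured step covers an aromatic ring in place of an alkoxy group at this position, so the expected step of a 2.1-fold higher number from compound 3 to compound 4 (0.31 log units; beyond the scatter) is held modest. For compound 4 in this assay the estimate is 350 nM, with a range from 120 nM to 1500 nM.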

Compound 4, half-maximal inhibitory concentration: 35 nM
Compound 4: the middle estimate sits 10-fold (1.00 log units) above what was measured, and the stated range ends above it.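

Placing 1-methyl-1H-pyrazol-4-yl on this aromatic carbon in place of 3-(4-methylpiperazin-1-yl)propoxy gives a 4.9-fold lower number from compound 3 to compound 4 (0.69 log units; beyond the scatter) in this assay, so the methylpiperazine-bearing chain is not needed here for the lowest number among these compounds. Compared with the short alkoxy groups, the same change gives an at least 14-fold lower number from compound 2 to compound 4 (1.15 log units; beyond the scatter) and an at least 14-fold lower number from compound 1 to compound 4 (1.15 log units; beyond the scatter), which places a directly attached aromatic ring ahead of all three alkoxy groups at this position. Those last two steps are lower bounds only: the limit of > 500 nM in this assay, at which 2 of the 4 values shown sit.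

Going by these compounds, whether the effect belongs to the pyrazole itself or to any aromatic ring on this carbon remains open; a phenyl or pyridine ring would address that. On these data alone, the role of the methyl on the pyrazole also remains open, as would be tested by the pyrazole without it or with a longer chain ending in an amine.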